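The source may hold more compounds than are shown below. What is called first, only, known or untested is meant among the compounds shown, and "the series" means these compounds.

Measured compounds:
compound 1 `O=C(Nc1cccc(-n2cc(-c3ccncc3)c(-c3ccc(Cl)c(O)c3)n2)c1)Nc1cccc(C(F)(F)F)c1`, 10800 nM
compound 2 `COc1cc(-c2nn(-c3cccc(NC(=O)Nc4ccc(Cl)c(C(F)(F)F)c4)c3)cc2-c2ccncc2)ccc1Cl`, 2580 nM

In a functional assay on SK-MEL-2 cells (Homo sapiens) for inhibition, read by sulforhodamine B assay, with a stated time of 48 h (on this read-out lower numbers stand for stronger inhibition of growth and higher numbers for weaker inhibition of growth), compound 2 gives the lower of the two numbers, and compound 1 gives 10800 nM, a gap beyond the scatter. Going by the values given here, compound 3 `O=C(Nc1cccc(-n2cc(-c3ccncc3)c(-c3ccc(Cl)c(O)c3)n2)c1)Nc1ccc(Cl)c(C(F)(F)F)c1` keeps the urea side of compound 2 and changes only one group: hydrogen in place of methyl on an oxygen on an aromatic ring, so methoxy becomes hydroxy, as in compound 1. Among the compounds with values here, no measured pair shows this change on its own, so its size in this assay is unknown; a small weakening or nothing beyond the scatter is expected, the step from a 1.6-fold higher number from compound 2 to compound 3 (0.19 log units; within the scatter). Compound 3 is therefore estimated at 4000 nM, within 1500 nM to 12000 nM.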

Compound 3, concentration for total growth inhibition: 1730 nM
Beside the measured number, compound 3's estimate is 2.3-fold (0.36 log units) above it; the measured number falls inside the stated range.
By their numbers in this assay, from the lowest: compounds 3 and 2 (each within the scatter of the next); then compound 1.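

In this assay, hydroxy in place of methoxy on the aromatic ring gives a 1.5-fold lower number from compound 2 to compound 3 (0.17 log units; within the scatter), so the two compounds cannot be told apart and this position accepts either group. On the urea side, chloro in place of hydrogen on an aromatic carbon gives a 6.2-fold lower number from compound 1 to compound 3 (0.80 log units; beyond the scatter), a modest step but one that clearly exceeds the scatter. No measurement here explains either result. Still open, on these data alone, is whether a longer chain such as ethoxy would fit on that oxygen, and whether fluoro or nitrile could replace the chloro.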